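The source may hold more compounds than are shown below. What is called first, only, known or untested is meant among the compounds shown, and "the series" means these compounds.

Within a functional assay on HCC827 cells (Homo sapiens) for antiproliferative activity, read by MTT assay, with a stated time of 72 h (on this read-out lower numbers stand for stronger inhibition and higher numbers for weaker inhibition), compound 3 `CN1CCN(c2ccc(Nc3ncc4nc(Nc5ccc(F)cc5)n([C@H]5CCN(C(=O)CO)C5)c4n3)cc2)CC1` gives 380 nM and stands highest of the three numbers measured; compound 1 `CNC(=O)CN1CC[C@H](n2c(Nc3ccccc3)nc3cnc(Nc4ccc(N5CCN(C)CC5)cc4)nc32)C1` gives 170 nM, and compound 2 `CC(=O)Nc1cccc(-n2c(Nc3ccc(F)cc3)nc3cnc(Nc4ccc(N5CCN(C)CC5)cc4)nc32)c1` gives 10 nM. Among the measured compounds shown here, the one step measured so far, a 38-fold higher number from compound 2 to compound 3 (1.58 log units; beyond the scatter), concerns a different exchange on the aromatic nitrogen and does not bear directly on the change at hand. Compound 4 `CNC(=O)CN1CC[C@H](n2c(Nc3ccc(F)cc3)nc3cnc(Nc4ccc(N5CCN(C)CC5)cc4)nc32)C1` differs from compound 3 by (methylcarbamoyl)methyl in place of (hydroxymethyl)carbonyl on an amine nitrogen in a ring. Compound 1 already carries this group on the ring nitrogen, and its value against that of compound 3 suggests a moderate drop in the number. For compound 4 the expected step is a 2.1-fold lower number from compound 3 to compound 4 (0.32 log units; beyond the scatter), so in this assay compound 4 is estimated at 180 nM, with a range from 70 nM to 450 nM.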

Compound 4, half-maximal inhibitory concentration: 1520 nM
Compound 4: middle estimate off by 8.4-fold (0.93 log units), on the low side; the whole stated range lies below it.
By their numbers in this assay, from the lowest: compound 2; then compound 1; then compound 3; then compound 4.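

In this assay, (methylcarbamoyl)methyl in place of (hydroxymethyl)carbonyl on the ring nitrogen gives a 4.0-fold higher number from compound 3 to compound 4 (0.60 log units; beyond the scatter), so the amide-bearing chain is the less favourable of these two groups in the fluoro series. Fluoro in place of hydrogen on an aromatic carbon gives an 8.9-fold higher number from compound 1 to compound 4 (0.95 log units; beyond the scatter), and 1-((methylcarbamoyl)methyl)pyrrolidin-3-yl in place of 3-acetamidophenyl gives a 150-fold higher number from compound 2 to compound 4 (2.18 log units; beyond the scatter), which widens the gap to the aryl compound. No measurement on hand accounts for these steps. Open, as far as these compounds go, is how a carboxylic acid or a longer chain on the ring nitrogen would read, and whether fluoro has a similar effect with 3-acetamidophenyl.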